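Amide-nitrogen substituent and cell toxicity across the shared core

The compounds below may be only part of what the source reports. "The series", "measured", "known", "first", "only" and "open" are said of these compounds alone.

Measured so far in an ADME assay on MT4 cells (Homo sapiens) for cytotoxicity, read by MTT assay, with a stated time of 5 days; on this read-out higher numbers stand for lower toxicity in this test and lower numbers for higher toxicity in this test:
compound 1 `Cc1cc(C)cc(S(=O)(=O)c2c(C(=O)N[C@H]3CCNC3)[nH]c3ccc(Cl)cc23)c1` — 10000 nM
compound 2 `Cc1cc(C)cc(S(=O)(=O)c2c(C(=O)N[C@@H]3CCN(CC(N)=O)C3)[nH]c3ccc(Cl)cc23)c1` — 31000 nM
compound 3 `Cc1cc(C)cc(S(=O)(=O)c2c(C(=O)NC3CN(Cc4n[nH]c(=O)n4C)C3)[nH]c3ccc(Cl)cc23)c1` — 25200 nM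

Compound 1 stands lowest of the three numbers, that is, it is the most toxic of the measured set in this read-out. From it, the step of a 3.1-fold higher number from compound 1 to compound 2 (0.49 log units; beyond the scatter) and the step of a 2.5-fold higher number from compound 1 to compound 3 (0.40 log units; beyond the scatter) both move upward by modest amounts. Between the two larger analogues the step of a 1.2-fold lower number from compound 2 to compound 3 (0.09 log units; within the scatter) stays within the scatter.

Compound 4 `Cc1cc(C)cc(S(=O)(=O)c2c(C(=O)NS(C)(=O)=O)[nH]c3ccc(Cl)cc23)c1` differs from compound 1 by methylsulfonyl in place of pyrrolidin-3-yl on an amide-type nitrogen. The two measured steps from compound 1 both change the group on the amide-type nitrogen, and both raise the number, so they bear on this step in place but not in kind: neither introduces a methylsulfonyl, and in neither does the ring leave entirely. With only a shared site and an upward tendency from two examples, the expectation is a step no larger than those seen, upward if anything, and quite possibly within the scatter.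

Compound 4 is therefore expected to give about 15000 nM, with a range from 6000 nM to 45000 nM. This estimate corresponds to an expected step of a 1.5-fold higher number from compound 1 to compound 4 (0.18 log units; within the scatter).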

Compound 4, half-maximal cytotoxic concentration: 40200 nM
For compound 4 the middle estimate is 2.7-fold (0.43 log units) below the measured one; measured number inside the range.
By their numbers in this assay, from the lowest: compound 1; then compounds 3, 2 and 4 (each within the scatter of the next).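

In this assay, pyrrolidin-3-yl can leave the amide-type nitrogen entirely, ring included, and the number still rises, with methylsulfonyl in its place giving a 4.0-fold higher number from compound 1 to compound 4 (0.60 log units; beyond the scatter), so a ring on this nitrogen is not needed to move away from the value of compound 1. The ring-free group also cannot be told apart from the two larger ring-bearing groups, since a 1.6-fold higher number from compound 3 to compound 4 (0.20 log units; within the scatter) and a 1.3-fold higher number from compound 2 to compound 4 (0.11 log units; within the scatter) both stay within the scatter, and among these four compounds only compound 1 stands apart, with no compound going against this. Nothing measured here gives a reason for these steps.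

Going by these compounds, it remains open whether the low number of compound 1 goes with its unsubstituted pyrrolidin-3-yl specifically, or whether a plain primary amine on a short alkyl chain would fall near compound 1 while a methyl group or a chain ending in a carboxylic acid would fall near compound 4. On these data alone, whether a sulfonyl group larger than methylsulfonyl, such as phenylsulfonyl, would stay level with compound 4 at this amide-type nitrogen is equally open.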